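This account rests on a few compounds, and the source may have more. Where it says the series, first, only, none or still open, it means among the compounds named here.

Working notes on the series. The shared core carries a tert-butyl benzamide linked through a benzylic amine to a second aromatic ring, and the variation sits on that second ring. In an assay on HeLa cells with Bile acid receptor (Homo sapiens) as the target, read by a luciferase reporter, with a stated time of 24 h (on this read-out lower numbers stand for an effect already at smaller amounts and higher numbers for an effect only at larger amounts of compound), compound 1 `CC(C)(C)c1ccc(C(=O)NCc2ccc(NS(C)(=O)=O)cc2)cc1` gives 44 nM. Compound 3 `CC(C)(C)c1ccc(C(=O)NCc2ccc(N)cc2Cl)cc1` gives 46 nM in this assay, and the two numbers lie within the scatter of each other, so no order between compound 1 and compound 3 can be read from them. Compound 2 `O=C(O)c1ccc(CNC(=O)c2ccc3ccccc3c2)cc1`, which replaces the tert-butyl phenyl with a naphthyl and carries a carboxylic acid on the benzylic ring, gives 1360 nM in this assay, a gap from compound 1 that lies beyond the scatter. On the numbers shown, compound 1 therefore stands at the low end, and only the gap to compound 2 separates it from its neighbours clearly.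

Compound 4 `CC(=O)Nc1ccc(CNC(=O)c2ccc(C(C)(C)C)cc2)cc1` is not yet measured. It differs from compound 1 by acetyl in place of methylsulfonyl on a nitrogen on an aromatic ring. For the measured compounds named here, no measured pair covers this change, so the expectation rests on compound 1 and on compound 3, where a bare amino group with a chloro on the same ring gives 46 nM, a value close to that of compound 1. The substituent on that nitrogen appears tolerant in this assay, so the expected step from compound 1 to compound 4 is a 1.6-fold higher number from compound 1 to compound 4 (0.20 log units; within the scatter), modest and within or near the scatter. Compound 4 is estimated at 70 nM in this assay, with a range from 25 nM to 200 nM.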

Compound 4, half-maximal effective concentration: 2900 nM
Beside the measured number, compound 4's estimate is 41-fold (1.62 log units) below it, and the stated range ends below it.
By their numbers in this assay, from the lowest: compounds 1 and 3 (each within the scatter of the next); then compound 2; then compound 4.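

In this assay, for the compounds shown here, the group on the nitrogen on the aromatic ring proves far less tolerant than the earlier compounds allowed one to see: methanesulfonamido to acetamido gives a 66-fold higher number from compound 1 to compound 4 (1.82 log units; beyond the scatter) in a single change. Going by these compounds alone, this is the first pair that differs in one place, and it shows that this position responds strongly to exchanging methylsulfonyl for acetyl, although neither group adds a hydrogen-bond donor or a net charge. Nothing at hand gives a measured reason for the size of this step.

Open, from the compounds shown here alone, is where an ethylsulfonyl group, with its longer chain, or a bare amine without the chloro would fall relative to compound 1 and compound 4. Also open, going by these compounds, is whether the same exchange gives a similar step on a core carrying naphthyl in place of the tert-butyl phenyl.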